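The source may report more compounds than this note shows. Statements on the series, on what has been measured and on what is new or still open speak of the compounds shown alone.

Compound 1 `Nc1cccc2c(-c3cccc(NC(=O)c4ccc5c(c4)OCCO5)c3)ccnc12` and compound 2 `CC(=O)Nc1cccc2c(-c3cccc(NC(=O)c4ccc5c(c4)OCCO5)c3)ccnc12` share one core; compound 2 differs from compound 1 by acetyl in place of hydrogen on a nitrogen on an aromatic ring. In a functional assay on SK-MEL-5 cells (Homo sapiens) for antiproliferative activity, read by sulforhodamine B assay, with a stated time of 48 h (a lower number here means a stronger inhibitor, a higher number a weaker inhibitor), compound 1 gives 45 nM, and compound 2 gives 56 nM; the step is a 1.2-fold higher number from compound 1 to compound 2 (0.09 log units; within the scatter). Compound 3 `Nc1cccc2c(-c3cccc(NC(=O)Nc4cc(C(F)(F)F)cc(C(F)(F)F)c4)c3)ccnc12` carries a different arm on the same core; the difference between the two cores is not broken down here. In this assay compound 3 gives 8700 nM, the highest number of the three. Compound 4 `CC(=O)Nc1cccc2c(-c3cccc(NC(=O)Nc4cc(C(F)(F)F)cc(C(F)(F)F)c4)c3)ccnc12` is not yet measured; it differs from compound 3 by acetyl in place of hydrogen on a nitrogen on an aromatic ring, the same change at the same place as from compound 1 to compound 2. Because the earlier step of a 1.2-fold higher number from compound 1 to compound 2 (0.09 log units; within the scatter) stayed within the scatter, the step from compound 3 to compound 4 is expected to be similar, a 1.1-fold higher number from compound 3 to compound 4 (0.06 log units; within the scatter). Compound 4 is therefore estimated at 10000 nM, between 4000 nM and 25000 nM in this assay.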

Compound 4, half-maximal inhibitory concentration: 18600 nM
For compound 4 the middle estimate is 1.9-fold (0.27 log units) below the measured one; the measured number falls inside the stated range.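

In this assay, acetyl in place of hydrogen on the aromatic amine nitrogen gives a 2.1-fold higher number from compound 3 to compound 4 (0.33 log units; beyond the scatter). Set beside the earlier step, the change reads alike on the two cores: the same change on two cores in this assay, a 1.2-fold higher number (0.09 log units; within the scatter) from compound 1 to compound 2 and a 2.1-fold higher number (0.33 log units; beyond the scatter) from compound 3 to compound 4, 1.7-fold (0.24 log units) apart, within the scatter of two such steps. This supports carrying the amino to acetamido change between these two cores with a similar outcome, but it rests on a single pair per core and shows neither a real dependence on the core nor that the result would hold on any other core.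

The compounds shown leave open how a longer acyl chain, a methanesulfonyl group or a simple methyl group on that nitrogen would read in this assay. As far as these compounds go, whether the step stays similar on a third arm also remains open.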